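This account rests on a few compounds, and the source may have more. Where it says the series, first, only, none or still open, it means among the compounds named here.

Compound 1 `CC(=O)O[C@@H]1C=CC(=O)O[C@@H]1[C@@H](COC(=O)c1ccc([N+](=O)[O-])cc1)OC(C)=O`: in an ADME assay on MRC5 cells (Homo sapiens) for cytotoxicity, read by MTT assay, with a stated time of 6 days (a higher number here means a weaker inhibitor, a lower number a stronger inhibitor), compound 1 gives > 100000 nM, which is a limit of the assay and not a number.
Compound 2 `O=C1C=C[C@@H](OCc2ccccc2)[C@@H]([C@@H](COC(=O)/C=C/c2ccccc2)OCc2ccccc2)O1`: in this assay compound 2 gives > 100000 nM, likewise a limit.
Compound 3 `CC(=O)OC[C@@H](OC(C)=O)[C@H]1OC(=O)C=C[C@H]1OC(C)=O`: in this assay compound 3 gives > 100000 nM, again a limit.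

On the numbers shown, compound 2 stands nowhere in particular: every value is a limit, so the limit of > 100000 nM in this assay, at which 3 of the 3 values shown sit, is all there is to say, and no compound can be ranked against another. Going by the values given here, the only measured step that can be traced, a step that the two limits leave unreadable from compound 1 to compound 3, has both ends at the limit and so offers no readable size. Compound 4 `CC(=O)OC[C@@H](OCc1ccccc1)[C@H]1OC(=O)C=C[C@H]1OCc1ccccc1` differs from compound 2 by methyl in place of 2-phenylethenyl on a carbonyl carbon. Among the compounds with values here, no measured step reports on this change with a readable size; the bare fact that all three measured compounds sit at the limit is the only guide. The expected step is a number no higher from compound 2 to compound 4 (the limit leaves the size open), which is to say no change beyond the scatter, with the result most likely reported again as a limit. Compound 4 is therefore estimated at 100000 nM, with a range from 30000 nM to 300000 nM.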

Compound 4, half-maximal inhibitory concentration: > 100000 nM
Compound 4 gave a limit, no number; the forecaster's own chance of this, stated with the estimate: 85%; the middle value lies on the limit itself.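

Compound 2 and compound 4 both give limits in this assay, not numbers, so no new step can be read between them. The compounds shown leave open whether any of these changes alters cytotoxicity, and they cannot be ranked, because all rest on one value: the limit of > 100000 nM in this assay, at which 4 of the 4 values shown sit.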